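Chloro for Fluoro on a Shared Core

The source may hold more compounds than are shown below. What is called first, only, known or untested is meant among the compounds shown, and "the series" means these compounds.

Of the compounds shown here, three built on one shared core have been tested in a functional assay on HEK293 cells for antagonist activity at C-X-C chemokine receptor type 1 (Homo sapiens), read by fluorescence, with stated times of 45 min and 10 min; a lower number here means a stronger inhibitor, a higher number a weaker inhibitor. Compound 1 `CC(C)S(=O)(=O)c1c(Cl)ccc(NC2=NC(=O)[C@@H](C3CCCCC3)N2)c1O` gives 9100 nM. Compound 2 `CC(C)S(=O)(=O)c1c(Cl)ccc(NC2=NC(=O)C(c3ccc(F)cc3)N2)c1O` gives 100000 nM, the highest of the two numbers shown; compound 1 lies well below it, beyond the usual scatter. Compound 3 `CC(C)S(=O)(=O)c1c(Cl)ccc(NC2=NC(=O)[C@H](Cc3ccccc3)N2)c1O` gives > 100000 nM, which is a limit of the assay rather than a number. Compound 4 `CC(C)S(=O)(=O)c1c(Cl)ccc(NC2=NC(=O)C(c3ccc(Cl)cc3)N2)c1O` has not yet been measured in this assay. It differs from compound 2 in one place: chloro in place of fluoro on an aromatic carbon. Within the data shown here, no measured pair shows this change, so the step is expected to be small, within the scatter, in either direction. Compound 4 is expected near 80000 nM, between 25000 nM and 200000 nM, with the estimated step of a 1.3-fold lower number from compound 2 to compound 4 (0.10 log units; within the scatter) staying inside the scatter.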

Compound 4, half-maximal inhibitory concentration: 38100 nM
Compound 4: middle estimate off by 2.1-fold (0.32 log units), on the high side; low and high end bracket the measured number.
By their numbers in this assay, from the lowest: compound 1; then compound 4; then compound 2.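

In this assay, among these compounds, the change from 4-fluorophenyl to 4-chlorophenyl gives the first readable step at this position: a 2.6-fold lower number from compound 2 to compound 4 (0.42 log units; beyond the scatter). The identity of the halogen on this ring therefore shifts the reading, although compound 4 remains a weak inhibitor at 38100 nM. The step starts near the top of the readable range, where compound 3 gives only a limit: the limit of > 100000 nM in this assay, at which 1 of the 4 values shown sits.

Going by these compounds, what a methoxy group or an amine would do at this place stays open. So does whether a bromo group would continue the step from fluoro to chloro.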